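Series notes: amide replacement at the carbonyl carbon

A few compounds are considered here, and "the series" means these few. Any claim that something is new, unique, unknown or untested is made for them only; others in the source may bear on it.

Three compounds of the shared core carry different groups on the carbonyl carbon. Compound 1 `O=C(C1CCC1)N1CCc2nc(C#Cc3ccccc3)sc2C1` reaches only the limit of an assay on HEK293 cells for positive allosteric modulation of metabotropic glutamate receptor 5 (Homo sapiens), read by FLIPR, with a stated time of 1 h (a lower number here means that less compound is needed, a higher number that more compound is needed for the effect), recorded as > 10000 nM, so it is a limit and not a number. Compound 2 `O=C(C1CCCO1)N1CCc2nc(C#Cc3ccccc3)sc2C1` gives 790 nM in this assay, and compound 3 `O=C(C1CCOCC1)N1CCc2nc(C#Cc3ccccc3)sc2C1` gives 290 nM, the lowest of the two numbers shown. The measured steps at this position are an at least 34-fold lower number from compound 1 to compound 3 (1.53 log units; beyond the scatter), an at least 12-fold lower number from compound 1 to compound 2 (1.10 log units; beyond the scatter) and a 2.7-fold lower number from compound 2 to compound 3 (0.44 log units; beyond the scatter); the first two rest on the limit described by the limit of > 10000 nM in this assay, at which 1 of the 3 values shown sits.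

Compound 4 `Cc1nc(C(=O)N2CCc3nc(C#Cc4ccccc4)sc3C2)cs1` differs from compound 3 by 2-methyl-1,3-thiazol-4-yl in place of oxan-4-yl on a carbonyl carbon. All measured steps exchange one non-aromatic ring for another on this carbon, and none brings in an aromatic ring, so they bear on the position but not on this change itself. For compound 4 in this assay the step is therefore expected to stay within the scatter, as a 1.2-fold higher number from compound 3 to compound 4 (0.08 log units; within the scatter), with wide uncertainty. Compound 4 is estimated at 350 nM, between 80 nM and 2000 nM.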

Compound 4, half-maximal effective concentration: 220 nM
For compound 4 the middle estimate is 1.6-fold (0.20 log units) above the measured one; the range from low to high includes it.
By their numbers in this assay, from the lowest: compounds 4 and 3 (each within the scatter of the next); then compound 2. At a limit, above all of these: compound 1.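

The first aromatic ring on this carbonyl carbon sits level with the best non-aromatic ring in this assay (a 1.3-fold lower number from compound 3 to compound 4 (0.12 log units; within the scatter)), so the position is not confined to non-aromatic rings, and 2-methyl-1,3-thiazol-4-yl and oxan-4-yl cannot be told apart here. Both lie on the same side of oxolan-2-yl, and for the aromatic ring that gap is beyond the scatter (a 3.6-fold lower number from compound 2 to compound 4 (0.56 log units; beyond the scatter)). The step with cyclobutyl (an at least 45-fold lower number from compound 1 to compound 4 (1.65 log units; beyond the scatter)) gives a bound and not a measured size, resting on a limit: the limit of > 10000 nM in this assay, at which 1 of the 4 values shown sits.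

With a single aromatic ring shown, the shares of its methyl group, its sulfur and its nitrogen in this result stay open. Phenyl, pyridin-3-yl or unsubstituted 1,3-thiazol-4-yl on this carbonyl carbon would test how far the result extends.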